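Furan shift on the shared core: compound 3 to compound 4

The source may hold more compounds than are shown below. What is called first, only, known or untested is meant among the compounds shown, and "the series" means these compounds.

Compound 3 `Nc1nc(N)c2c(-c3ccoc3)cn([C@@H]3O[C@H](CO)[C@@H](O)[C@H]3O)c2n1` stands at the upper limit of a functional assay on A549 cells (Homo sapiens), read by MTT assay, with a stated time of 72 h; on this read-out higher numbers stand for weaker inhibition and lower numbers for stronger inhibition: in this assay compound 3 gives > 20000 nM, a limit rather than a number. Compound 2 `Nc1nc(N)c2c(-c3ccccc3)cn([C@@H]3O[C@H](CO)[C@@H](O)[C@H]3O)c2n1` likewise gives > 20000 nM in this assay, a limit. Compound 1 `Cc1nc(N)c2c(-c3ccco3)cn([C@@H]3O[C@H](CO)[C@@H](O)[C@H]3O)c2n1` gives > 20000 nM in this assay, again a limit. Among the measured compounds shown here, the only one-place step among the measured compounds, a step that the two limits leave unreadable from compound 2 to compound 3, is left unreadable by these limits, and the limit of > 20000 nM in this assay, at which 3 of the 3 values shown sit, shows that every value so far sits at that limit, so no step size can be read from the set. Compound 4 `Nc1nc(N)c2c(-c3ccco3)cn([C@@H]3O[C@H](CO)[C@@H](O)[C@H]3O)c2n1` differs from compound 3 by furan-2-yl in place of furan-3-yl on an aromatic carbon. For the measured compounds named here, no measured step bears on this change, so no direction beyond the scatter is expected. Compound 4 is expected at 30000 nM, with a range from 10000 nM to 100000 nM, most likely reported once more as a limit. The expected step is a step that the limit leaves unreadable from compound 3 to compound 4.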

Compound 4, half-maximal inhibitory concentration: > 20000 nM
Compound 4: no number, only a limit; the forecaster's own chance of this, stated with the estimate: 85%; the middle value does not contradict the limit.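

Compound 4 gives only a limit, so its steps from compound 1, compound 2 and compound 3 cannot be read: the limit of > 20000 nM in this assay, at which 4 of the 4 values shown sit. The compounds shown leave open whether any of these group changes on the shared core alters inhibition.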